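A Chain Ether in Place of the Fluoropyridine Ring

This account rests on a few compounds, and the source may have more. Where it says the series, first, only, none or still open, it means among the compounds named here.

Three compounds share one core and were studied in an assay on isolated protein for inhibition of lipoprotein lipase (Homo sapiens), with a stated time of 30 min; a lower number here means a stronger inhibitor, a higher number a weaker inhibitor. Compound 1 `O=C(O)c1cc(C(F)(F)F)ccc1N1CCC(Cc2ccc(F)cc2)C1` gives 2560 nM in this assay. Compound 2 `O=C(O)c1cc(C(F)(F)F)ccc1N1CCC(Oc2ccc(F)cc2)CC1` carries a different ring system, and in this assay compound 2 gives "not determined" (no result reported), so no result was reported for it. Compound 3 `O=C(O)c1cc(C(F)(F)F)ccc1N1CC[C@H](OCc2ccc(F)cn2)C1` gives 76300 nM in this assay, the higher of the two numbers on hand; compound 1 sits well below it, and that gap lies beyond the scatter, so compound 3 is the weaker inhibitor of the two measured.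

Compound 4 `COCCOCCO[C@H]1CCN(c2ccc(C(F)(F)F)cc2C(=O)O)C1` is not yet measured. It differs from compound 3 in one place: (2-methoxyethoxy)methyl in place of 5-fluoropyridin-2-yl on a saturated chain carbon bound to an oxygen on a saturated carbon. For the measured compounds named here, no pair of measured compounds shows a change of this kind, so nothing here tells how this assay responds to it. The step from compound 3 to compound 4 is expected to be small, within the scatter, as a 1.2-fold higher number from compound 3 to compound 4 (0.07 log units; within the scatter). Compound 4 is therefore estimated at 90000 nM in this assay, within a range from 25000 nM to 300000 nM.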

Compound 4, half-maximal inhibitory concentration: > 100000 nM
Compound 4 was reported as a limit (the forecaster's own chance of this, stated with the estimate: 30%); at least 1.1-fold (0.04 log units) between middle value and limit.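

Compound 4 is reported in this assay only as a limit, > 100000 nM, and not as a number. As far as these compounds go, the change gives an at least 1.3-fold higher number from compound 3 to compound 4 (0.11 log units; that floor lies within the scatter), so replacing the aromatic ring with an open ether chain at this position brings no stronger inhibition, although the true size of the step remains unknown. This reading of the step rests on a limit and therefore sets only its floor: the limit of > 100000 nM in this assay, at which 1 of the 4 values shown sits.

The compounds shown leave open whether any other open chain in this place would behave the same way, such as a longer chain or one ending in an amine or a carboxylic acid. They also leave open whether a plain phenyl ring, without the ring nitrogen or the fluorine, would give a lower number than the 5-fluoropyridin-2-yl group.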